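This account rests on a few compounds, and the source may have more. Where it says the series, first, only, none or still open, it means among the compounds named here.

Two compounds have been measured so far in a functional assay on OVCAR-8 cells (Homo sapiens) for inhibition, read by sulforhodamine B assay, with a stated time of 48 h, tested at 10 uM; on this read-out higher numbers stand for a weaker effect at the one concentration tested and lower numbers for a stronger effect:

compound 1, `COc1cc2cc(Oc3ccc(NC(=O)Nc4ccccc4)cc3)c(C)nc2cc1OC`, with 71.9%
compound 2, `COc1cc2cc(Oc3ccc(NC(=O)Nc4ccc(C)cc4)cc3)c(C)nc2cc1OC`, with 87.4%

On this read-out compound 2 holds the higher of the two numbers, which here means the weaker effect at the one concentration tested; the step of a number 15.5 percentage points higher from compound 1 to compound 2 (beyond the scatter) lies beyond the scatter of repeated measurements. Compound 3, `COc1cc2cc(Oc3ccc(NC(=O)Nc4ccc(C(F)(F)F)cc4)cc3)c(C)nc2cc1OC`, has not yet been measured. It differs from compound 2 in one place: trifluoromethyl in place of methyl on an aromatic carbon. Within the data shown here, only one measured step exists, the one from compound 1 to compound 2, and it concerns a methyl entering in place of hydrogen, not a trifluoromethyl entering in place of methyl, so it does not speak directly to this change. Nothing measured here shows how a trifluoromethyl at this position behaves. The expectation therefore rests on compound 2 alone, and the step of a number 2.4 percentage points lower from compound 2 to compound 3 (within the scatter) is expected to stay within the scatter. Compound 3 is estimated at 85%, with a range from 65% to 100%.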

Compound 3, a percentage reported as activity, at one concentration (the size of the read-out at that concentration, not a potency): 37.8%
Beside the measured number, compound 3's estimate is 47.2 percentage points above it; the measured number lies below the stated range.
By their numbers in this assay, from the lowest: compound 3; then compound 1; then compound 2.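

This position on the aromatic ring, para to a large group, turns out to be sensitive to what sits there. In this assay, trifluoromethyl in place of methyl gives a number 49.6 percentage points lower from compound 2 to compound 3 (beyond the scatter), so two groups that both lack a ring and hydrogen-bond donors or acceptors can behave very differently here. Trifluoromethyl in place of hydrogen gives a number 34.1 percentage points lower from compound 1 to compound 3 (beyond the scatter), while methyl in place of hydrogen gives a number 15.5 percentage points higher from compound 1 to compound 2 (beyond the scatter), so the two groups move the read-out in opposite directions from the unsubstituted compound, and compound 3 has the strongest effect of the three at the one concentration tested; no measurement shown here explains this split.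

The compounds shown leave open whether the gain belongs to trifluoromethyl alone or extends to other groups at this position, such as a chlorine atom, a nitrile, a methoxy group or an amine. They also leave open whether trifluoromethyl would do the same elsewhere on this ring, and how strong the effect of compound 3 would be at any other concentration, as only the size of its effect at the one concentration tested is known.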